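The compounds below may be only part of what the source reports. "The series", "measured", "known", "first", "only" and "open" are said of these compounds alone.

Series notes. Compound 3 `CS/C(=N\C(=O)c1cnc2ccccc2c1)NC(=O)c1cnc2ccccc2c1` and compound 2 `C[Se]/C(=N\C(=O)c1cnc2ccccc2c1)NC(=O)c1cnc2ccccc2c1` share one core and differ by a group of 2 heavy atoms (1 carbon, 1 selenium; no ring) in place of a group of 2 heavy atoms (1 carbon, 1 sulfur; no ring), on a carbon with a double bond to nitrogen. Compound 1 `CS/C(=N\C(=O)c1sccc1Cl)NC(=O)c1sccc1Cl` carries the methylsulfanyl group on a second core; the difference between the two cores is not broken down here. Compound 4 `C[Se]/C(=N\C(=O)c1sccc1Cl)NC(=O)c1sccc1Cl` is the selenium counterpart of compound 1 and has not yet been measured.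

In a functional assay on MCF7 cells (Homo sapiens) for cytotoxicity, read by MTT assay, with a stated time of 72 h (a higher number here means that more compound is tolerated, a lower number that less compound is tolerated), compound 3 gives only a limit, > 100000 nM. Compound 2 gives 60700 nM in this assay. The step of an at least 1.6-fold lower number from compound 3 to compound 2 (0.21 log units; that floor lies within the scatter) therefore rests on a limit and is only a floor. Compound 1 also gives only a limit in this assay, > 100000 nM. Two of the three values sit at the limit of > 100000 nM in this assay, at which 2 of the 3 values shown sit, so the series is poorly resolved at the low-toxicity end.

The change from compound 1 to compound 4 is a group of 2 heavy atoms (1 carbon, 1 selenium; no ring) in place of a group of 2 heavy atoms (1 carbon, 1 sulfur; no ring), on a carbon with a double bond to nitrogen, the same change as from compound 3 to compound 2, at the same place. The step expected is an at least 1.4-fold lower number from compound 1 to compound 4 (0.15 log units; that floor lies within the scatter) in this assay. This rests on compound 2 at 60700 nM. It also rests on the step of an at least 1.6-fold lower number from compound 3 to compound 2 (0.21 log units; that floor lies within the scatter), which is only a floor and leaves the true size open. Compound 4 is estimated at 70000 nM, expected between 30000 nM and 150000 nM, with a real chance that only a limit is reported.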

Compound 4, concentration lethal to 50% of the cells: > 100000 nM
Compound 4 was reported as a limit; the forecaster's own chance of this, stated with the estimate: 45%; at least 1.4-fold (0.15 log units) between middle value and limit.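

Compound 1 and compound 4 both give only limits in this assay, so no step can be read between them. The compounds shown leave open how large the exchange of methylsulfanyl for its selenium counterpart is on either core, as compound 2 alone gives a number and the others share one limit: the limit of > 100000 nM in this assay, at which 3 of the 4 values shown sit.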